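Swapping a phenyl for a basic side chain on the acyl group

A few compounds are considered here, and "the series" means these few. Any claim that something is new, unique, unknown or untested is made for them only; others in the source may bear on it.

Measured so far:
compound 1, `CC(=O)Oc1ccccc1C1CC(C)=NN1C(=O)CCl`, gives 2520 nM
compound 2, `O=C(c1ccccc1)N1N=C(c2cc3ccccc3oc2=O)CC1c1ccccc1`, gives 36600 nM

Both compounds were tested in a functional assay on HepG2 cells (Homo sapiens) for cytotoxicity, read by MTT assay, with a stated time of 48 h; a higher number here means a weaker inhibitor, a lower number a stronger inhibitor. Of the two numbers, compound 2 has the higher one, so it is the weaker inhibitor of the pair; compound 1 sits well below it, and the gap between them is beyond the usual scatter. The two compounds share no single point of difference, so nothing more can be read from the pair than what the two values show.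

Compound 3, `CN1CCN(CC(=O)N2N=C(c3cc4ccccc4oc3=O)CC2c2ccccc2)CC1`, has not yet been measured. It differs from compound 2 in one place:

(4-methylpiperazin-1-yl)methyl in place of phenyl on a carbonyl carbon

The acyl group on the ring nitrogen thus goes from benzoyl to ((4-methylpiperazin-1-yl)methyl)carbonyl. For the measured compounds named here, no measured pair in this small set shows what such a change does, so there is no step to lean on. Without such a step, the expectation is a step from compound 2 to compound 3 of a 1.5-fold lower number from compound 2 to compound 3 (0.17 log units; within the scatter), small and not clearly beyond the scatter. Compound 3 is therefore estimated at 25000 nM, within a range of 8000 nM to 80000 nM.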

Compound 3, half-maximal inhibitory concentration: 33100 nM
The estimate for compound 3 lay 1.3-fold (0.12 log units) below the measured number; measured number inside the range.
By their numbers in this assay, from the lowest: compound 1; then compounds 3 and 2 (each within the scatter of the next).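

In this assay, for the compounds shown here, the first comparison that changes only one place gives a 1.1-fold lower number from compound 2 to compound 3 (0.04 log units; within the scatter), so on this carbonyl carbon the two groups cannot be told apart by this read-out. That holds even though the exchange is a substantial one on paper: a six-membered aromatic ring of carbon only, with 0 hydrogen-bond acceptors, gives way to (4-methylpiperazin-1-yl)methyl, a non-aromatic ring with 2 hetero atoms and 2 hydrogen-bond acceptors. Nothing measured on these compounds speaks to the reason for this result.

One pair cannot show whether this position accepts almost any group in this assay, or whether these two simply happen to fall close together, and a carboxylic acid, a simple primary amine or a longer carbon chain ahead of the piperazine ring on the same carbonyl carbon would test that. Compound 1, at 2520 nM, differs from compound 2 and compound 3 in more than one place, so which of its features goes with its number remains an open question.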